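A few compounds are considered here, and "the series" means these few. Any claim that something is new, unique, unknown or untested is made for them only; others in the source may bear on it.

Measured so far:
compound 1, `COc1ccc(-c2nc3cc(/C=C4\SC(=O)N(CC(=O)N5CCOCC5)C4=O)ccc3[nH]2)cc1OC`; in a functional assay on PC-3 cells (Homo sapiens) for inhibition, read by MTT assay, with a stated time of 48 h (a lower number here means a stronger inhibitor, a higher number a weaker inhibitor), compound 1 gives > 50000 nM, which is a limit of the assay.
compound 2, `COc1cc(OC)c(-c2nc3cc(/C=C4\SC(=O)N(CC(=O)N5CCOCC5)C4=O)ccc3[nH]2)cc1OC`; in this assay compound 2 gives 11700 nM.

Within the data shown here, compound 2 therefore holds the only number in the set; the other value is a limit. Among the measured compounds shown here, the one measured step, an at least 4.2-fold lower number from compound 1 to compound 2 (0.63 log units; beyond the scatter), concerns a change on the aromatic ring and not the position varied next. Compound 3 is `COc1cc(OC)c(-c2nc3cc(/C=C4\SC(=O)N(Cc5cccc(C)c5)C4=O)ccc3[nH]2)cc1OC`, differing from compound 2 by 3-methylphenyl in place of (morpholin-4-yl)carbonyl on a saturated chain carbon bound to an amide-type nitrogen in a ring. For the measured compounds named here, no measured step bears on this change, so its direction rests on no evidence here. A step of a 2.3-fold lower number from compound 2 to compound 3 (0.37 log units; beyond the scatter) is expected, taken as a modest move. Compound 3 is estimated at 5000 nM, with a range from 1200 nM to 25000 nM.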

Compound 3, half-maximal inhibitory concentration: 630 nM
Compound 3: the middle estimate sits 7.9-fold (0.90 log units) above what was measured; the whole stated range lies above it.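

In this assay, 3-methylphenyl in place of (morpholin-4-yl)carbonyl gives a 19-fold lower number from compound 2 to compound 3 (1.27 log units; beyond the scatter), so the substituent on this saturated chain carbon can move the number substantially. Both earlier compounds carry the (morpholin-4-yl)carbonyl group, so they gave no reading of this position. Nothing measured here accounts for the step. The compounds shown leave open whether the step depends on the methyl group, as against an unsubstituted benzyl, or on the aromatic ring itself, as against a longer alkyl chain or a carboxylic acid.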